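The source may report more compounds than this note shows. Statements on the series, on what has been measured and on what is new or still open speak of the compounds shown alone.

The account begins with compound 1 `COCC[C@@H]1C[C@H]1c1cncc(N2CCCNCC2)c1`, which in an assay on SH-EP1 cells for agonist activity at Neuronal acetylcholine receptor; alpha4/beta2 (Homo sapiens), read by rubidium efflux, with a stated time of 9.5 min (a lower number here means a smaller maximal response, a higher number a larger maximal response), gives 63%. Compound 2 `COCC[C@H]1C[C@@H]1c1cncc(N2CCCN(C)CC2)c1` carries a methyl on the ring nitrogen of its seven-membered ring and is the mirror image of compound 1 at the two ring carbons; in this assay compound 2 gives "not determined" (no result reported), so there is no single number for compound 2 to stand on, and nothing further can be said of where it sits. The step from compound 2 leads to compound 3 `COCC[C@H]1C[C@@H]1c1cncc(N2CCCNCC2)c1`, where the change is hydrogen in place of methyl on an amine nitrogen in a ring. Compound 2 supplies no value in this assay, and the size of this step cannot be anchored on compound 2 itself. The only measured point nearby is compound 1 with 63%, which shares with compound 3 the unsubstituted ring nitrogen but not the arrangement at the ring carbons. Any expectation for the direction of the step therefore rests on that single number, and a change of modest size, within or only somewhat beyond the scatter, is expected rather than a large one. For compound 3 in this assay a maximal response of 55% is expected, in the range 20% to 90%.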

Compound 3, largest response reached (reported as efficacy), in percent of the reference or control that the assay uses: 81%
Beside the measured number, compound 3's estimate is 26 percentage points below it; the measured number falls inside the stated range.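

Among the compounds shown here, compounds 1 and 3 form the first pair that can be compared in this assay, and the comparison gives a number 18 percentage points higher from compound 1 to compound 3 (beyond the scatter). For the compounds shown here, this shows that the maximal response at this receptor is sensitive to the arrangement at the two ring carbons, which the single value available earlier could not show. The step can be assigned to configuration alone because of one fact: the fact that compounds 1 and 3 differ only in the configuration as drawn. With hydrogen on the amine nitrogen of the seven-membered ring, the arrangement drawn in compound 3 is therefore the one with the larger maximal response of this pair.

On these data alone, the step from compound 2 to compound 3 cannot be read, and the effect of methyl in place of hydrogen on that nitrogen remains unknown for either arrangement at the ring carbons. Also open, as far as these compounds go, are how an ethyl group on the same nitrogen would behave, and whether the difference between the mirror images would persist with such a group or with only one of the two stereocentres inverted.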